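The source may report more compounds than this note shows. Statements on the series, on what has been measured and on what is new or still open speak of the compounds shown alone.

Readings in an ADME assay on HEK-293T cells (Homo sapiens) for cytotoxicity, read by CCK-8 assay, with a stated time of 48 h; on this read-out higher numbers stand for weaker inhibition and lower numbers for stronger inhibition:

compound 1 `O=C(NCCNS(=O)(=O)c1ccc(-c2ccccc2O[C@H]2CC[C@H](O)CC2)s1)Nc1ccc([N+](=O)[O-])cc1`: 9000 nM
compound 2 `O=C(NCCNS(=O)(=O)c1ccc(-c2ccccc2Oc2ccc([N+](=O)[O-])c([N+](=O)[O-])c2)s1)Nc1cc(Cl)cc(Cl)c1`: > 20000 nM (a limit, not a number)

Compound 2 stands at the limit of > 20000 nM in this assay, at which 1 of the 2 values shown sits. It therefore gives a floor for comparison and no exact reference point.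

Compound 3 `O=C(NCCNS(=O)(=O)c1ccc(-c2ccccc2O[C@H]2CC[C@H](O)CC2)s1)Nc1cc(Cl)cc(Cl)c1` differs from compound 2 in one place: 4-hydroxycyclohexyl in place of 3,4-dinitrophenyl on an oxygen on an aromatic ring. Going by the values given here, no pair of measured compounds differing in one place is available, so the effect of this change has not been observed directly in this assay.

Among the compounds with values here, the only other evidence is that the 4-hydroxycyclohexyl group is also present in compound 1, which gives 9000 nM. On that basis, a move towards a lower number, meaning stronger inhibition, is expected, though of uncertain size. A reading that again reaches only the limit remains possible.

The expected change is an at least 2.0-fold lower number from compound 2 to compound 3 (0.30 log units; that floor lies within the scatter). Compound 3 is estimated at 10000 nM. The expected range for this estimate runs from 4000 nM to 20000 nM.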

Compound 3, half-maximal inhibitory concentration: > 50000 nM
Compound 3: only a limit was reported (the forecaster's own chance of this, stated with the estimate: 30%); middle value at least 5.0-fold (0.69 log units) from the limit.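

In this assay, compound 3 is reported only as a limit, not as a number: the limit of > 50000 nM in this assay, at which 1 of the 3 values shown sits. With the 4-hydroxycyclohexyl group held constant on the oxygen on an aromatic ring, 3,5-dichlorophenyl in place of 4-nitrophenyl on an amide-type nitrogen gives an at least 5.5-fold higher number from compound 1 to compound 3 (0.74 log units; beyond the scatter); this step lies beyond the scatter, so the group on that nitrogen changes the read-out in this pair, and the 4-hydroxycyclohexyl group alone does not fix the reading at the level of compound 1. The step for 4-hydroxycyclohexyl in place of 3,4-dinitrophenyl cannot be read, since both compounds in that pair are reported only as limits, and the pair gives neither a direction nor a size for this change.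

Still open, from the compounds shown here alone, is whether any group on the oxygen on an aromatic ring moves the reading when 3,5-dichlorophenyl stays on the amide-type nitrogen, a question that a pair with numerical values would settle. Also open, going by these compounds, is how a simple amine or a carboxylic acid in place of 4-hydroxycyclohexyl would read, and whether 4-nitrophenyl on the amide-type nitrogen would give a readable comparison for the change at the oxygen.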